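Swapping a Pyrrolidinylmethyl for a Methyltriazole: Expected Cytotoxicity

The source may report more compounds than this note shows. Statements on the series, on what has been measured and on what is new or still open speak of the compounds shown alone.

Measured compounds:
compound 1, `O=C(Nc1cccc(CN2CCCC2)c1)C1CCCN(C(=O)c2cc(C(F)(F)F)cc(C(F)(F)F)c2)C1`: 51%
compound 2, `C=Cc1cccc(C(=O)N2CCCC(C(=O)Nc3ccc(Cl)cc3)C2)c1`: 0%

In an ADME assay on PC-3 cells (Homo sapiens) for cytotoxicity, read by WST assay, tested at 100 uM (on this read-out higher numbers stand for more inhibition at the one concentration tested (going by the name of the read-out) and lower numbers for less inhibition), compound 1 gives 51%, the higher of the two numbers, while compound 2 gives 0%, a gap well beyond the usual scatter. Compound 3, `Cn1cnnc1-c1cccc(NC(=O)C2CCCN(C(=O)c3cc(C(F)(F)F)cc(C(F)(F)F)c3)C2)c1`, has not yet been measured. It differs from compound 1 in one place: 4-methyl-4H-1,2,4-triazol-3-yl in place of (pyrrolidin-1-yl)methyl on an aromatic carbon. Among the compounds with values here, no measured pair shows this exact change, so its size is uncertain; a drop in this assay beyond the scatter is expected. For compound 3 the estimate is 20%, within 0% to 50%. That corresponds to an expected step of a number 31 percentage points lower from compound 1 to compound 3 (beyond the scatter).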

Compound 3, a percentage reported as inhibition, at one concentration (the size of the read-out at that concentration, not a potency): 0%
Compound 3: the middle estimate sits 20 percentage points above what was measured; the range from low to high includes it.
By their numbers in this assay, from the lowest: compounds 2 and 3 (each within the scatter of the next); then compound 1.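

In this assay, within the data shown here, the exchange of (pyrrolidin-1-yl)methyl for 4-methyl-4H-1,2,4-triazol-3-yl on this aromatic carbon brings a number 51 percentage points lower from compound 1 to compound 3 (beyond the scatter) and is the first one-place change seen here. The shared core alone does not carry the inhibition: compound 3 holds it and reads 0% here. Nothing measured here says why the step is so large.

Still open, going by these compounds, is which part of (pyrrolidin-1-yl)methyl matters, the ring or its carbon link to the aromatic ring. A dimethylaminomethyl or a morpholin-4-ylmethyl group at this place would help separate the two.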